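The source may hold more compounds than are shown below. What is called first, only, known or untested is meant among the compounds shown, and "the series" means these compounds.

Measured compounds:
- compound 1 `O=c1[nH]c(-c2cccc3ccccc23)nc2ccc(N3CCCCC3)cc12` gives 2240 nM
- compound 2 `Cc1ccc2nc(-c3ccccc3OC(F)(F)F)[nH]c(=O)c2c1` gives 2790 nM
- compound 3 `COc1cccc(-c2nc3ccc(N4CCCCC4)cc3c(=O)[nH]2)c1OC` gives 24800 nM

All three were tested in a functional assay on HCT-15 cells (Homo sapiens) for cytotoxicity, read by MTT assay, with a stated time of 2 days; on this read-out lower numbers stand for stronger inhibition and higher numbers for weaker inhibition. Compound 1 has the lowest number of the three. Compound 2 lies close to it, within the usual scatter, so the two cannot be set in order. Compound 3 stands far from compound 1, beyond the scatter, so on these numbers compound 3 is clearly the weaker of that pair.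

The piece follows the step from compound 1 to compound 4 `Cc1ccc2nc(-c3cccc4ccccc34)[nH]c(=O)c2c1`, which has not yet been measured in this assay. The change is methyl in place of piperidin-1-yl on an aromatic carbon. The shared core and the aryl group on it are kept; only the substituent on the fused six-membered carbon ring is exchanged. Compound 2 carries the same methyl at that position with a different aryl group, and its value of 2790 nM sits near that of compound 1, which gives some footing for the expectation.

Among the compounds with values here, no step between measured compounds that differ in one place is available here. The step is therefore expected to be small, with a slight drift towards a higher number, if any, and within or just at the edge of the scatter: a 1.6-fold higher number from compound 1 to compound 4 (0.19 log units; within the scatter). Compound 4 is estimated at 3500 nM, with a range from 1200 nM to 10000 nM.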

Compound 4, half-maximal inhibitory concentration: > 50000 nM
Compound 4: a limit, no number (the forecaster's own chance of this, stated with the estimate: 5%); middle value at least 14-fold (1.15 log units) from the limit.
By their numbers in this assay, from the lowest: compounds 1 and 2 (each within the scatter of the next); then compound 3. At a limit, above all of these: compound 4.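

In this assay, methyl in place of piperidin-1-yl on this aromatic carbon gives an at least 22-fold higher number from compound 1 to compound 4 (1.34 log units; beyond the scatter), so with the aryl group of compound 1 kept, the position is far from indifferent to what it carries. Compound 4 reaches a limit and not a number, and the step from compound 1 therefore has no upper end: the limit of > 50000 nM in this assay, at which 1 of the 4 values shown sits. Compound 2 carries the same methyl at that position with a different aryl group and gives 2790 nM, so methyl there can go with a measured number, and what the exchange does depends on the aryl group that accompanies it.

Going by these compounds, what remains open is which part of piperidin-1-yl matters at this carbon: whether a morpholine ring, an open amine such as dimethylamino, or a plain butyl chain would stay near compound 1 or fall towards compound 4. Within the data shown here, also open is how methyl or piperidin-1-yl would behave across a wider set of aryl groups, including the one in compound 3, given that the effect of this exchange has been read with the aryl group of compound 1 alone.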